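This account rests on a few compounds, and the source may have more. Where it says the series, first, only, none or still open, it means among the compounds named here.

Measured compounds:
compound 1 `COC(=O)c1ccc(CN(CCCc2c(N)nc(N)nc2O)c2ccc([N+](=O)[O-])c(F)c2F)cc1`, 45000 nM
compound 3 `COC(=O)c1ccc(CN(CCCc2c(N)nc(N)nc2O)c2cc(F)ccc2[N+](=O)[O-])cc1`, 30000 nM
compound 2 `CC(C)(C)OC(=O)CCC(Nc1ccc(CN(CCCc2c(N)nc(N)nc2O)c2cc(F)ccc2[N+](=O)[O-])cc1)C(=O)OC(C)(C)C`, 14000 nM

In a functional assay on CCRF-CEM cells (Homo sapiens) for cytotoxicity, in the presence of a further agent that is not named here (on this read-out higher numbers stand for weaker inhibition and lower numbers for stronger inhibition), compound 3 gives 30000 nM and compound 1 gives 45000 nM. The difference between them is 2,3-difluoro-4-nitrophenyl in place of 5-fluoro-2-nitrophenyl on an amine nitrogen, and the step is a 1.5-fold higher number from compound 3 to compound 1 (0.18 log units; within the scatter). Compound 2, with the glutamate-type diester in place of the methyl ester, gives 14000 nM in this assay; how the core of compound 2 differs from the core of compound 3 is not broken down here. Compound 2 stands lowest of the three measured numbers, and both of its steps to the others are beyond the scatter.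

Compound 4 `CC(C)(C)OC(=O)CCC(Nc1ccc(CN(CCCc2c(N)nc(N)nc2O)c2ccc([N+](=O)[O-])c(F)c2F)cc1)C(=O)OC(C)(C)C` is not yet measured. It differs from compound 2 by 2,3-difluoro-4-nitrophenyl in place of 5-fluoro-2-nitrophenyl on an amine nitrogen, the same change, at the same kind of place, that was made from compound 3 to compound 1. Because that earlier step was a 1.5-fold higher number from compound 3 to compound 1 (0.18 log units; within the scatter), the step from compound 2 to compound 4 is expected to be of similar size, about a 1.5-fold higher number from compound 2 to compound 4 (0.18 log units; within the scatter). On that basis compound 4 is estimated at 21000 nM in this assay, with a likely span from 8000 nM to 50000 nM.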

Compound 4, half-maximal inhibitory concentration: 20000 nM
Beside the measured number, compound 4's estimate is 1.1-fold (0.02 log units) above it; low and high end bracket the measured number.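

In this assay, putting 2,3-difluoro-4-nitrophenyl in place of 5-fluoro-2-nitrophenyl on the amine nitrogen gives a 1.4-fold higher number from compound 2 to compound 4 (0.15 log units; within the scatter). Set beside the earlier step, the same change behaves alike on the two cores, with no difference that can be told apart: the same change on two cores in this assay, a 1.5-fold higher number (0.18 log units; within the scatter) from compound 3 to compound 1 and a 1.4-fold higher number (0.15 log units; within the scatter) from compound 2 to compound 4, 1.1-fold (0.02 log units) apart, within the scatter of two such steps. This shows that, on these two cores, the swap leaves the read-out within the usual scatter, but it does not show that the change truly shifts the number in either case, and two cores say nothing about how it would behave on a third core or in another assay.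

The compounds shown leave open whether the same agreement would hold with a free carboxylic acid in place of the tert-butyl esters or the methyl ester, or with a longer chain on the amine nitrogen. They also leave open how a phenyl group carrying an amine in place of the nitro group would compare on either core.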